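Swapping an oxadiazole for a sulfonamide on the cyclopentyl amine

The compounds below may be only part of what the source reports. "The series", "measured", "known", "first", "only" and "open" are said of these compounds alone.

Of the compounds shown here, three sharing one core have been measured in an assay on isolated protein for inhibition of eIF-2-alpha kinase GCN2 (Homo sapiens); on this read-out lower numbers stand for stronger inhibition and higher numbers for weaker inhibition. Compound 1 `Cc1nn(-c2ccc3ncccc3c2)c2nc(Nc3cnn(C4CCNCC4)c3)ncc12` gives 11 nM. Compound 2 `COCCC(=O)N[C@@H]1CC[C@@H](Nc2ncc3c(Br)nn(-c4ccc5ncccc5c4)c3n2)C1` gives 74 nM, and compound 3 `COCc1noc([C@@H]2CC[C@@H](Nc3ncc4c(Br)nn(-c5ccc6ncccc6c5)c4n3)C2)n1` gives 106 nM, the highest of the three numbers, although its gap to compound 2 is within the scatter, while compound 1 sits clearly lower. Compound 4 `COCCS(=O)(=O)N[C@@H]1CC[C@@H](Nc2ncc3c(Br)nn(-c4ccc5ncccc5c4)c3n2)C1` differs from compound 3 by a group of 8 heavy atoms (3 carbon, 1 nitrogen, 3 oxygen, 1 sulfur; no ring) in place of a group of 8 heavy atoms (4 carbon, 2 nitrogen, 2 oxygen; one five-membered aromatic ring with 3 hetero atoms), on a saturated ring carbon. Going by the values given here, the only comparable step, a 1.4-fold higher number from compound 2 to compound 3 (0.16 log units; within the scatter), shows that exchanging the group at this position between an open chain and a small ring changed little. On that basis the expected step of a 1.3-fold lower number from compound 3 to compound 4 (0.12 log units; within the scatter) is small, with no clear direction. Compound 4 is therefore estimated at 80 nM, within a range of 30 nM to 250 nM.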

Compound 4, half-maximal inhibitory concentration: 55 nM
For compound 4 the middle estimate is 1.5-fold (0.16 log units) above the measured one, and the stated range covers the measured number.
By their numbers in this assay, from the lowest: compound 1; then compounds 4, 2 and 3 (each within the scatter of the next).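

In this assay, a 1.9-fold lower number from compound 3 to compound 4 (0.28 log units; within the scatter) and, with (2-methoxyethyl)sulfonyl in place of (2-methoxyethyl)carbonyl on an amine nitrogen, a 1.3-fold lower number from compound 2 to compound 4 (0.13 log units; within the scatter). An amide, a sulfonamide and a five-membered aromatic ring on this saturated ring carbon thus all give numbers within the scatter of one another, so the linking group can be exchanged here with no clear effect on the read-out. No measurement at hand explains this. Still open, from the compounds shown here alone, is whether a free amine, a carboxylic acid or a longer chain at this position would behave the same way.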